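Series notes: side chain on the cyanoguanidine nitrogen

A few compounds are considered here, and "the series" means these few. Any claim that something is new, unique, unknown or untested is made for them only; others in the source may bear on it.

Three compounds share one core and differ only in the group on the double-bonded nitrogen. Compound 1 `CCCCC/N=C(\NC#N)Nc1cccnc1` carries a pentyl chain; in a functional assay on the whole organism (blood, strain Wistar-Okamoto) with Rattus norvegicus as the target, with a stated time of 5 days (a higher number here means that more compound is needed for the effect, a lower number that less compound is needed), compound 1 gives 20 mg/kg. Compound 3 `CCC(C)/N=C(\NC#N)Nc1cccnc1` carries sec-butyl, and in this assay compound 3 gives 20 mg/kg; the step of no change at the digits printed from compound 1 to compound 3 (within the scatter) shows that sec-butyl in place of pentyl leaves the dose unchanged. Compound 2 `CC(C)(C)C/N=C(/NC#N)Nc1cccnc1` carries neopentyl, and in this assay compound 2 gives 2.5 mg/kg, the lowest of the three numbers, with its gap to compound 1 and to compound 3 in each case beyond the scatter.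

Compound 4 `CC(/N=C(/NC#N)Nc1cccnc1)C(C)(C)C` differs from compound 2 by methyl in place of hydrogen on a saturated chain carbon bound to a double-bonded nitrogen and a saturated chain carbon, read one bond further out as neopentyl to 1,2,2-trimethylpropyl. Going by the values given here, no measured pair shows this exact change. Among the compounds with values here, the only measured step, from compound 1 to compound 3, exchanges one chain for another at the same nitrogen without effect, so a change of this size within the chain is taken as unlikely to move the dose beyond the scatter. Compound 4 is therefore expected to stay near compound 2, at an estimated 4 mg/kg (range 1.5 mg/kg to 12 mg/kg), which means an expected step of a 1.6-fold higher number from compound 2 to compound 4 (0.20 log units; within the scatter).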

Compound 4, minimum effective dose: 1 mg/kg
Compound 4: middle estimate off by 4.0-fold (0.60 log units), on the high side, outside the stated range (below it).
By their numbers in this assay, from the lowest: compound 4; then compound 2; then compounds 1 and 3 (each within the scatter of the next).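

In this assay, methyl in place of hydrogen on a saturated chain carbon bound to a double-bonded nitrogen and a saturated chain carbon gives a 2.5-fold lower number from compound 2 to compound 4 (0.40 log units; beyond the scatter), a modest step, so this position of the side chain does respond to a single added methyl. Going by these compounds alone, the only earlier step between single chains, no change at the digits printed from compound 1 to compound 3 (within the scatter), showed no such response, and the new pair therefore shows that the side chain is not indifferent to every small change, at least on going from neopentyl to 1,2,2-trimethylpropyl. No measurement on hand bears on why the number moves at this carbon, so the step stands as an observation only.

The compounds shown leave open whether the lower number is particular to methyl at this carbon or would also hold for ethyl, hydroxymethyl or cyclopropyl there. They also leave open whether the same methyl would lower the number on the pentyl chain of compound 1, or whether the step belongs to the neopentyl chain of compound 2 alone.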